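This account rests on a few compounds, and the source may have more. Where it says the series, first, only, none or still open, it means among the compounds named here.

Measured compounds:
compound 1 `O=C1NC(=O)/C(=C/c2ccc(OCCSc3nnc(-c4ccc([N+](=O)[O-])cc4)[nH]3)cc2)S1` — 13.9%
compound 2 `O=C1NC(=O)/C(=C/c2ccc(OCCSc3nnc(-c4ccccc4)o3)cc2)S1` — 14.6%

Two compounds share one core and differ only in the group on the five-membered aromatic ring. In a functional assay on the whole organism (plasma, strain Wistar) with Rattus norvegicus as the target, with a stated time of 15 days, at a dose of 10 mg/kg by the oral route (on this read-out higher numbers stand for a stronger effect at the one dose given and lower numbers for a weaker effect), compound 2 gives 14.6%, which places it at the top of the two numbers shown. Compound 1 gives 13.9% in this assay, and since that number sits within the usual scatter of compound 2, the two cannot be told apart on this read-out; neither one can be called the stronger.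

Compound 3 `O=C1NC(=O)/C(=C/c2ccc(OCCSc3nnc(Cc4ccccc4)o3)cc2)S1` has not yet been measured. It differs from compound 2 by a single change: benzyl in place of phenyl on an aromatic carbon. Within the data shown here, no measured pair shows what this change does, so nothing in the data points to a direction. Among the measured compounds shown here, with both measured numbers close together and no step of this kind on record, compound 3 is expected to land near compound 2, and the expected step of a number 0.6 percentage points lower from compound 2 to compound 3 (within the scatter) in this assay is one that stays within the scatter. The estimate for compound 3 in this assay is 14%, with a likely range from 4% to 26%.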

Compound 3, a percentage reported as activity, at one dose (the size of the read-out at that dose, not a potency): 16.8%
Compound 3: middle estimate off by 2.8 percentage points, on the low side, and the stated range covers the measured number.
By their numbers in this assay, from the lowest: compounds 1, 2 and 3 (each within the scatter of the next).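

Among these compounds, the step from phenyl to benzyl is the first one on record at this position, since the two compounds measured earlier offered no pair that differed in one place. On the aromatic carbon of the five-membered ring with 2 nitrogen and 1 oxygen, in this assay, benzyl in place of phenyl gives a number 2.2 percentage points higher from compound 2 to compound 3 (within the scatter), so this read-out does not separate the two groups at this position, and a carbon-only six-membered aromatic ring is present in both of them. No measured finding accounts for the result or gives a property of either group.

The compounds shown leave open whether a group of another kind on this carbon, such as an amine, a carboxylic acid or a longer chain ending in a phenyl ring, would produce a step beyond the scatter in this assay. They also leave open whether a methoxy group or a chlorine atom on the aromatic ring of the benzyl group would change the read-out at this dose.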